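This account rests on a few compounds, and the source may have more. Where it says the series, first, only, none or still open, it means among the compounds named here.

Measured so far in an ADME assay on HeLa cells (Homo sapiens) for inhibition, read by MTT assay; on this read-out lower numbers stand for stronger inhibition of growth and higher numbers for weaker inhibition of growth:

Compound 1 `Cc1ccc(O)c(C(=O)/C=C/c2cn(-c3ccc(F)cc3)nc2-c2sc(C)nc2C)c1` gives 29.9 ug/mL.
Compound 2 `Cc1nc(C)c(-c2nn(-c3ccc(F)cc3)cc2/C=C/C(=O)c2cc(Cl)cc(Cl)c2O)s1` is reported only as a limit, > 250 ug/mL.
Compound 3 `Cc1nc(C)c(-c2nn(-c3ccc(F)cc3)cc2C2CC(c3cc(Br)ccc3O)=NN2)s1` gives 21.6 ug/mL.

Compound 3 holds the lowest of the two numbers; compound 1 lies within the scatter of it, so no order between them is claimed. Compound 2 stands at the limit of > 250 ug/mL in this assay, at which 1 of the 3 values shown sits, and gives no number.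

Compound 4 `Cc1nc(C)c(-c2nn(-c3ccc(F)cc3)cc2C2CC(c3cc(Cl)ccc3O)=NN2)s1` differs from compound 3 by chloro in place of bromo on an aromatic carbon. Within the data shown here, the one measured step, an at least 8.3-fold higher number from compound 1 to compound 2 (0.92 log units; beyond the scatter), concerns a different part of the series and a different pair of groups, so it does not bear directly on a single halogen swap. Among the measured compounds shown here, no measured step speaks to bromo against chloro here. The expectation is therefore a step of no size beyond the scatter, a 1.2-fold higher number from compound 3 to compound 4 (0.06 log units; within the scatter). Compound 4 is estimated at 25 ug/mL, within 10 ug/mL to 60 ug/mL.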

Compound 4, concentration for 50% growth inhibition: > 250 ug/mL
Compound 4: no number, only a limit; the forecaster's own chance of this, stated with the estimate: 10%; at least 10-fold (1.00 log units) between middle value and limit.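

In this assay the change to chloro from bromo para to the hydroxy group gives an at least 11-fold higher number from compound 3 to compound 4 (1.06 log units; beyond the scatter) and shows that this position, untouched by the earlier step, responds strongly to a swap of one halogen for another. The entry for compound 4 is a limit and not a number, so the full size of the step cannot be read: the limit of > 250 ug/mL in this assay, at which 2 of the 4 values shown sit.

Going by these compounds, whether iodo, methoxy or nitrile at this position would read like bromo or like chloro remains open.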